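The compounds below may be only part of what the source reports. "The series", "measured", "known", "first", "only" and "open" are said of these compounds alone.

Measured in a physicochemical assay for solubility, at pH 7.4; on this read-out lower numbers stand for lower solubility and higher numbers for higher solubility:

- compound 1 `Cc1cc(NC(=O)Nc2ccccc2F)c2ccccc2n1` gives 3800 nM
- compound 2 `Cc1cc(NC(=O)Nc2ccc(O)cc2)c2ccccc2n1` gives 100 nM
- compound 3 `Cc1cc(NC(=O)Nc2ccccc2N)c2ccccc2n1` gives 51800 nM

Compound 2 stands lowest of the three, with a 38-fold lower number from compound 1 to compound 2 (1.58 log units; beyond the scatter) and a 520-fold higher number from compound 2 to compound 3 (2.71 log units; beyond the scatter) separating it from the other two. Compound 4 `Cc1cc(NC(=O)Nc2ccc(C(N)=O)cc2)c2ccccc2n1` is compound 2 with one change: carbamoyl in place of hydroxy on an aromatic carbon. Within the data shown here, no measured step exchanges exactly these two groups. Still, the steps of a 38-fold lower number from compound 1 to compound 2 (1.58 log units; beyond the scatter), a 14-fold higher number from compound 1 to compound 3 (1.13 log units; beyond the scatter) and a 520-fold higher number from compound 2 to compound 3 (2.71 log units; beyond the scatter) all show that a single change on this ring moves this assay by large amounts, in both directions. Since compound 2 already holds the lowest number, a carbamoyl in that place is expected to give a moderate rise, a 10-fold higher number from compound 2 to compound 4 (1.00 log units; beyond the scatter), with wide uncertainty. Compound 4 is therefore estimated at 1000 nM, between 200 nM and 8000 nM.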

Compound 4, solubility: 900 nM
Compound 4: the middle estimate sits 1.1-fold (0.05 log units) above what was measured, within the range that was stated.
By their numbers in this assay, from the lowest: compound 2; then compound 4; then compound 1; then compound 3.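

Replacing hydroxy with carbamoyl at this position on the ring raises the number in this assay (a 9.0-fold higher number from compound 2 to compound 4 (0.95 log units; beyond the scatter)). This shows that the position can hold a larger group without the number falling, and that the number can move even when the counted hydrogen-bond donors and acceptors stay the same. No measurement here offers a reason for the rise. Still open, from the compounds shown here alone, is how an amine, a carboxylic acid or a longer chain at this same position would compare with carbamoyl and hydroxy.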